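Sulfonyl substituent variation in cyanoguanidine antiproliferatives

This account rests on a few compounds, and the source may have more. Where it says the series, first, only, none or still open, it means among the compounds named here.

Measured so far:
compound 1 `N#C/N=C(\NCc1ccc(S(=O)(=O)c2ccccc2)cc1)Nc1cccnc1` — 30 nM
compound 2 `N#C/N=C(\NCc1ccc(S(=O)(=O)c2cccc(C(F)(F)F)c2)cc1)Nc1ccncc1` — 2.9 nM
compound 3 `N#C/N=C(\NCc1ccc(S(=O)(=O)N2CC3CCC(C2)O3)cc1)Nc1cccnc1` — 175 nM

In a functional assay on A2780 cells (Homo sapiens) for antiproliferative activity, read by sulforhodamine B assay, with a stated time of 72 h (a higher number here means a weaker inhibitor, a lower number a stronger inhibitor), compound 2 gives the lowest number of the three; compound 1 is beyond the scatter above it, and compound 3 further still. Compound 4 `N#C/N=C(\NCc1ccc(S(=O)(=O)C2CCCCC2)cc1)Nc1ccncc1` differs from compound 2 by cyclohexyl in place of 3-(trifluoromethyl)phenyl on a sulfonyl sulfur. Within the data shown here, the one measured step on the sulfonyl sulfur is a 5.8-fold higher number from compound 1 to compound 3 (0.77 log units; beyond the scatter), where a saturated bicyclic group replaced the aromatic ring and the number rose. Compound 1 and compound 2 differ in two places, so their gap cannot be assigned to either. A saturated ring entering in compound 4 is expected to cost some potency in this assay, by a step of a 3.4-fold higher number from compound 2 to compound 4 (0.54 log units; beyond the scatter), smaller than the bicyclic case. Compound 4 is therefore estimated at 10 nM (range 3 nM to 40 nM).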

Compound 4, half-maximal inhibitory concentration: 14.8 nM
Compound 4: the middle estimate sits 1.5-fold (0.17 log units) below what was measured, and the stated range covers the measured number.
By their numbers in this assay, from the lowest: compound 2; then compound 4; then compound 1; then compound 3.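

In this assay, a 5.1-fold higher number from compound 2 to compound 4 (0.71 log units; beyond the scatter) shows that the number also rises when a plain carbocycle replaces an aromatic group on the sulfonyl sulfur. Even so, compound 4 gives 14.8 nM, so an aromatic ring at this position is not required for activity at this level. The change removes the aromatic ring and the trifluoromethyl together, so their contributions cannot be separated, and no measurement here explains the rise.

Still open, from the compounds shown here alone, is how an open-chain butyl group or a piperidine on the sulfonyl sulfur would read. So is the effect of an amine or a carboxylic acid on the cyclohexyl ring.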